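Adding a further methoxy to the series

The compounds below may be only part of what the source reports. "The series", "measured", "known", "first", "only" and "open" are said of these compounds alone.

In a functional assay on FM3A cells (Mus musculus) for antiproliferative activity, with a stated time of 48 h (on this read-out lower numbers stand for stronger inhibition and higher numbers for weaker inhibition), compound 1 (`COc1ccccc1/C=C/C(=O)c1ccc(N)cc1`) gives 25000 nM and compound 2 (`COc1cccc(/C=C/C(=O)c2ccc(N)cc2)c1OC`) gives 29000 nM. On these two numbers, the only ones available so far, compound 2 lies within the scatter of compound 1, so neither can be ranked over the other.

Compound 3 (`COc1ccc(/C=C/C(=O)c2ccc(N)cc2)c(OC)c1OC`) arises from compound 2 by methoxy in place of hydrogen on an aromatic carbon. This is methoxy in place of hydrogen on an aromatic carbon, and the carbon concerned is ortho to a methoxy group, meta to a methoxy group and para to a large group.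

For the measured compounds named here, one measured step bears on this change, as it is the same replacement made at another place on the ring: a 1.2-fold higher number from compound 1 to compound 2 (0.06 log units; within the scatter). With that single precedent inside the scatter, no step beyond the scatter is expected in this assay, and no direction is favoured. The expected step is a 1.2-fold lower number from compound 2 to compound 3 (0.06 log units; within the scatter). Going by the values given here, the estimated value for compound 3 is 25000 nM, with an expected range of 10000 nM to 60000 nM, kept wide because only one step supports it.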

Compound 3, half-maximal inhibitory concentration: 29000 nM
Compound 3: middle estimate off by 1.2-fold (0.06 log units), on the low side; the measured number falls inside the stated range.
By their numbers in this assay, from the lowest: compounds 1, 2 and 3 (each within the scatter of the next).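

In this assay, the aromatic carbon that is ortho to a methoxy group, meta to a methoxy group and para to a large group accepts a further methoxy with no change at the digits printed from compound 2 to compound 3 (within the scatter), so this position shows no measurable response to the change. Read beside a 1.2-fold higher number from compound 1 to compound 2 (0.06 log units; within the scatter), the same replacement has now been tested at two places on the ring, and at both the step stays within the scatter; what was a single precedent is now a pair of steps that agree, with compound 3 at 29000 nM still in the same range as its neighbour. Nothing measured on these compounds beyond the antiproliferative numbers bears on this result, so the notes stop at the numbers themselves.

Still open, as far as these compounds go, is whether this carbon responds to anything other than methoxy, for example a hydroxy group, an amine, a carboxylic acid or a longer chain such as butoxy, since a replacement of that kind could yet give a step beyond the scatter. Also open, from the compounds shown here alone, is whether removing or exchanging the methoxy groups already on the ring would change the number.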